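Adding an Isopropyl to the Amide Chain of Compound 2

This account rests on a few compounds, and the source may have more. Where it says the series, first, only, none or still open, it means among the compounds named here.

Measured in a functional assay on A549 cells (Homo sapiens) for antiproliferative activity, read by CCK-8 assay, with a stated time of 72 h; a higher number here means a weaker inhibitor of growth, a lower number a stronger inhibitor of growth:
compound 1 `CCCCNS(=O)(=O)c1ccc(Nc2ncc3c(n2)N(C2CCCC2)[C@H](CC)C(=O)N3C)cc1`: 477 nM
compound 2 `CC[C@@H]1C(=O)N(C)c2cnc(-n3ccc4cc(C(=O)NC)ccc43)nc2N1C1CCCC1`: 2200 nM

Of these two compounds, compound 2 has the highest number, at 2200 nM, which makes it the weaker inhibitor of growth. The nearest and only comparison is compound 1, whose 477 nM lies lower by more than the usual scatter of repeated measurements. These two compounds differ in more than one place, so their gap says little about any single change.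

Compound 3 `CC[C@@H]1C(=O)N(C)c2cnc(-n3ccc4cc(C(=O)NCC(C)C)ccc43)nc2N1C1CCCC1` is compound 2 with one change: isopropyl in place of hydrogen on a saturated chain carbon bound to an amide-type nitrogen. Put another way, methylcarbamoyl becomes isobutylcarbamoyl. For the measured compounds named here, no measured pair of compounds shows this change, so the data offer no direct guide to its effect in this assay. The expected outcome is therefore a cautious one: no step beyond the scatter, with a slight lean toward a lower number. The estimate amounts to an expected 1.5-fold lower number from compound 2 to compound 3 (0.17 log units; within the scatter). For compound 3 the estimated value is 1500 nM, with an expected range from 450 nM to 5000 nM.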

Compound 3, concentration for 50% growth inhibition: 1730 nM
For compound 3 the middle estimate is 1.2-fold (0.06 log units) below the measured one, within the range that was stated.
By their numbers in this assay, from the lowest: compound 1; then compounds 3 and 2 (each within the scatter of the next).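

In this assay, the first direct test at this position, replacing methylcarbamoyl with isobutylcarbamoyl gives a 1.3-fold lower number from compound 2 to compound 3 (0.10 log units; within the scatter) and so does not separate the two compounds. The amide chain of compound 2 therefore accepts an added isopropyl, on a saturated chain carbon bound to an amide-type nitrogen, with no step beyond the usual scatter of repeated measurements in this growth read-out. No measurement at hand offers an explanation for this result.

A single step cannot show a trend with chain size, so the isobutyl result cannot be extended to other groups at this position. As far as these compounds go, it remains open whether a longer chain such as n-hexyl, a ring such as cyclohexyl, or a chain ending in an amine or a carboxylic acid would leave the number within the scatter or move it beyond.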